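Chalcone-pyrazole series: aryl ketone swap, cytotoxicity at one dose

The source may hold more compounds than are shown below. What is called first, only, known or untested is meant among the compounds shown, and "the series" means these compounds.

Measured so far:
compound 1, `COc1cc(-c2cc(/C=C/C(=O)c3ccc(N)cc3)[nH]n2)cc(OC)c1OC`: 110%
compound 2, `COc1ccc(C(=O)/C=C/c2cc(-c3cc(OC)c(OC)c(OC)c3)n[nH]2)cc1OC`: 100%

Both numbers come from a functional assay on OVCAR-3 cells (Homo sapiens) for cytotoxicity, read by sulforhodamine B assay, with a stated time of 48 h, tested at 0.1 uM; a higher number here means a weaker effect of the compound at the concentration tested, a lower number a stronger effect. Compound 1 gives 110% and compound 2 gives 100%; the two values lie within the usual scatter of each other, so neither compound shows an effect at this concentration that can be separated from the other. Going by the values given here, the single step known, a number 10 percentage points lower from compound 1 to compound 2 (within the scatter), swaps one aryl group on the carbonyl carbon for another without any change beyond the scatter.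

Compound 3, `COc1cc(-c2cc(/C=C/C(=O)c3ccc(F)c(F)c3)[nH]n2)cc(OC)c1OC`, is the next member. Its difference from compound 2 is 3,4-difluorophenyl in place of 3,4-dimethoxyphenyl on a carbonyl carbon. Among the compounds with values here, this is again an exchange of the aryl group on the carbonyl carbon, the same kind of move as the one measured step, which stayed within the scatter. On that basis no step beyond the scatter is expected: the estimate is no change at the digits printed from compound 2 to compound 3 (within the scatter), with compound 3 expected at 100% in this assay, between 80% and 120%.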

Compound 3, a percentage reported as activity, at one concentration (the size of the read-out at that concentration, not a potency): 104%
Compound 3: middle estimate off by 4 percentage points, on the low side; low and high end bracket the measured number.
By their numbers in this assay, from the lowest: compounds 2, 3 and 1 (each within the scatter of the next).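

On the carbonyl carbon, 3,4-difluorophenyl now stands alongside 3,4-dimethoxyphenyl and 4-aminophenyl, and this assay gives a number 4 percentage points higher from compound 2 to compound 3 (within the scatter) and a number 6 percentage points lower from compound 1 to compound 3 (within the scatter). The group that enters counts 0 hydrogen-bond acceptors where 3,4-dimethoxyphenyl counts 2, so at this position, among these three aryl groups and at this single concentration, replacing methoxy with fluorine on the ring leaves the read-out within the scatter, as does replacing the amino-bearing ring with either of the others. Nothing available bears on why these exchanges leave the read-out unmoved.

On these data alone, all three compounds sit at one concentration, so it stays open whether these aryl groups would separate from one another at a higher dose, where a read-out well away from the level seen here could show differences. Also open, as far as these compounds go, is whether a different kind of group on the carbonyl carbon, such as a methyl group or a pyridyl ring, or a carboxylic acid on the aryl ring, would give a step beyond the scatter.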